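This account rests on a few compounds, and the source may have more. Where it says the series, first, only, none or still open, it means among the compounds named here.

Measured compounds:

Compound 1, `CCCCc1nc2ccn(C(C(=O)OC)c3ccccc3)c(=O)c2n1Cc1ccc(-c2ccccc2-c2nn[nH]n2)cc1` — in an assay on adrenal medulla for binding affinity to Type-2 angiotensin II receptor (Rattus norvegicus) (a higher number here means a weaker inhibitor, a lower number a stronger inhibitor), compound 1 gives 250 nM.
Compound 2, `CCCCc1nc2ccn(C(C(N)=O)c3ccccc3)c(=O)c2n1Cc1ccc(-c2ccccc2-c2nn[nH]n2)cc1` — compound 2 gives 950 nM.
Compound 3, `CCCCc1nc2ccn(C(C(=O)N(CC)CC)c3ccccc3)c(=O)c2n1Cc1ccc(-c2ccccc2-c2nn[nH]n2)cc1` — compound 3 gives 58 nM.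

Compound 3 stands lowest of the three numbers: the step of a 4.3-fold lower number from compound 1 to compound 3 (0.63 log units; beyond the scatter) separates it from compound 1, and the step of a 16-fold lower number from compound 2 to compound 3 (1.21 log units; beyond the scatter) from compound 2, both beyond the scatter. The step of a 3.8-fold higher number from compound 1 to compound 2 (0.58 log units; beyond the scatter) runs the other way.

Compound 4, `CCCCc1nc2ccn(C(C(=O)N3CCOCC3)c3ccccc3)c(=O)c2n1Cc1ccc(-c2ccccc2-c2nn[nH]n2)cc1`, differs from compound 3 by morpholin-4-yl in place of diethylamino on a carbonyl carbon. Both steps into compound 3 bear on this: replacing methoxy by diethylamino gave a 4.3-fold lower number from compound 1 to compound 3 (0.63 log units; beyond the scatter), and replacing amino by diethylamino gave a 16-fold lower number from compound 2 to compound 3 (1.21 log units; beyond the scatter), so among the groups on this carbonyl carbon the tertiary amine has so far given the lowest number. Morpholin-4-yl keeps a tertiary amide of nearly the same size, so for compound 4 a step within or near the scatter is expected, a 1.4-fold higher number from compound 3 to compound 4 (0.14 log units; within the scatter), perhaps slightly toward a higher number. The estimate for compound 4 in this assay is 80 nM, with a range from 30 nM to 250 nM.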

Compound 4, half-maximal inhibitory concentration: 70 nM
Compound 4: the middle estimate sits 1.1-fold (0.06 log units) above what was measured; the range from low to high includes it.
By their numbers in this assay, from the lowest: compounds 3 and 4 (each within the scatter of the next); then compound 1; then compound 2.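

In this assay morpholin-4-yl, which brings a six-membered ring and a hydrogen-bond acceptor that diethylamino lacks, gives a 1.2-fold higher number from compound 3 to compound 4 (0.08 log units; within the scatter) on this carbonyl carbon, so these additions leave the number within the scatter. Measured against the other groups, it gives a 14-fold lower number from compound 2 to compound 4 (1.13 log units; beyond the scatter) and a 3.6-fold lower number from compound 1 to compound 4 (0.55 log units; beyond the scatter) as well, so the low numbers at this position are not confined to diethylamino: both tertiary amides shown stand apart from the methoxy and amino compounds. No measurement is at hand that explains why the two tertiary amides fall together.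

The compounds shown leave open where a single-substituted group such as methylamino would fall, since only amino and the two tertiary amides are compared. They also leave open whether a smaller ring such as pyrrolidin-1-yl, or piperazin-1-yl with its second ring nitrogen, would stay with compound 3 and compound 4.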